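Phenyl versus formyl on the ring nitrogen of a pyrazoline series

A few compounds are considered here, and "the series" means these few. Any claim that something is new, unique, unknown or untested is made for them only; others in the source may bear on it.

Compound 1 `Fc1ccc(C2=NN(c3ccccc3)C(c3cn(-c4ccccc4)nc3-c3ccc(Cl)c(Cl)c3)C2)cc1`: 44.7%
Compound 2 `Clc1ccc(C2=NN(c3ccccc3)C(c3cn(-c4ccccc4)nc3-c3ccc(Cl)c(Cl)c3)C2)cc1`: 45.7%
Compound 3 `Cc1ccc(C2=NN(C=O)C(c3cn(-c4ccccc4)nc3-c3ccc(Cl)c(Cl)c3)C2)cc1`: 35.1%

Of the compounds shown here, three sharing one core have been tested in a functional assay on the whole organism (strain Wistar) for inhibition, with Rattus norvegicus as the target, read by paw edema, with a stated time of 30 min, at a dose of 50 mg/kg by the oral route; a higher number here means more inhibition at the dose given (going by the name of the read-out), a lower number less inhibition. Going by the values given here, compound 1 gives 44.7% and compound 2 gives 45.7%; the only measured step, a number 1 percentage points higher from compound 1 to compound 2 (within the scatter), is within the scatter. Compound 3 gives 35.1%, the lowest of the three numbers; its gap to compound 1 is within the scatter, while its gap to compound 2 lies beyond it.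

Compound 4 `Cc1ccc(C2=NN(c3ccccc3)C(c3cn(-c4ccccc4)nc3-c3ccc(Cl)c(Cl)c3)C2)cc1` has not yet been measured. It differs from compound 3 in one place: phenyl in place of formyl on an amine nitrogen in a ring. Among the compounds with values here, no measured step covers this change. Within the data shown here, the one measured step, from compound 1 to compound 2, concerns a halogen on an aromatic carbon and says nothing about the ring nitrogen. What the data do show is that compounds 1 and 2, both carrying phenyl on that nitrogen, give numbers above compound 3, which carries formyl.

On that basis compound 4 is expected to give a number close to compounds 1 and 2, an upward step from compound 3 of about a number 8.9 percentage points higher from compound 3 to compound 4 (within the scatter), at the edge of the scatter. The estimate for compound 4 in this assay is 44%, with a range from 34% to 54%.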

Compound 4, a percentage reported as inhibition, in the whole organism at one dose (the size of the read-out at that dose, not a potency): 46.8%
Compound 4: middle estimate off by 2.8 percentage points, on the low side; measured number inside the range.
By their numbers in this assay, from the lowest: compounds 3, 1, 2 and 4 (each within the scatter of the next, the first and the last beyond it).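

In this assay the change of phenyl in place of formyl on the amine nitrogen in the ring now has a step of its own, a number 11.7 percentage points higher from compound 3 to compound 4 (beyond the scatter) with the 4-methylphenyl group the same on both sides, so the comparison at this nitrogen no longer has to be made across different aromatic substituents. The substituent on the aromatic carbon shows no such separation among the compounds carrying phenyl on that nitrogen: methyl in place of chloro gives a number 1.1 percentage points higher from compound 2 to compound 4 (within the scatter) and methyl in place of fluoro gives a number 2.1 percentage points higher from compound 1 to compound 4 (within the scatter) in the same assay. Among the compounds shown, the one single-place step beyond the scatter therefore lies at the ring nitrogen, while methyl does not stand apart from the two halogens.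

Going by these compounds, with only phenyl and formyl seen on that nitrogen, it remains open whether the higher number goes with the phenyl ring or with the loss of formyl, a question that an acetyl, benzyl or methyl group there could help to separate. Nothing available here bears on what lies behind the step.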